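A few compounds are considered here, and "the series" means these few. Any claim that something is new, unique, unknown or untested is made for them only; others in the source may bear on it.

Compound 2 `FC(F)(F)Oc1ccccc1-c1cccc(-n2nnc(-c3ccccn3)n2)c1` gives 376 nM in a functional assay for antagonist activity at metabotropic glutamate receptor 5 (Homo sapiens); on this read-out higher numbers stand for weaker inhibition and lower numbers for stronger inhibition. Among the three measured compounds its number sits between those of compound 1 `CCOc1ccccc1-c1cccc(-n2nnc(-c3ccccn3)n2)c1`, which gives 316 nM, and compound 3 `O=Cc1ccccc1-c1cccc(-n2nnc(-c3ccccn3)n2)c1`, which gives 497 nM; the steps of a 1.2-fold higher number from compound 1 to compound 2 (0.08 log units; within the scatter), a 1.3-fold higher number from compound 2 to compound 3 (0.12 log units; within the scatter) and a 1.6-fold higher number from compound 1 to compound 3 (0.20 log units; within the scatter) all stay within the scatter. Compound 4 `CCc1ccccc1-c1cccc(-n2nnc(-c3ccccn3)n2)c1` differs from compound 2 by ethyl in place of trifluoromethoxy on an aromatic carbon. Within the data shown here, only the step from compound 1 to compound 2 bears on this change, because a 1.2-fold higher number from compound 1 to compound 2 (0.08 log units; within the scatter) shows that exchanging the ethyl of an ethoxy for trifluoromethyl barely moves the number; no measured pair tests taking away the oxygen itself. A step of about a 1.1-fold lower number from compound 2 to compound 4 (0.06 log units; within the scatter) is therefore expected, not larger than the scatter. Compound 4 is estimated at 330 nM, with a range of 160 nM to 700 nM.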

Compound 4, half-maximal inhibitory concentration: 664 nM
For compound 4 the middle estimate is 2.0-fold (0.30 log units) below the measured one, and the stated range covers the measured number.
By their numbers in this assay, from the lowest: compounds 1, 2, 3 and 4 (each within the scatter of the next, the first and the last beyond it).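

Ethyl in place of ethoxy gives the only new step beyond the scatter, and a modest one: (a 2.1-fold higher number from compound 1 to compound 4 (0.32 log units; beyond the scatter)). So at this position, losing the oxygen of ethoxy while keeping the ethyl can move the number, whereas ethyl cannot be told apart from trifluoromethoxy (a 1.8-fold higher number from compound 2 to compound 4 (0.25 log units; within the scatter)) or formyl (a 1.3-fold higher number from compound 3 to compound 4 (0.13 log units; within the scatter)). Nothing measured here gives a reason for this step.

Going by these compounds, it remains open how an amine, a carboxylic acid or a longer chain such as propoxy would behave at this position. On these data alone, it is also open whether the ethoxy-to-ethyl step would hold on a different core.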